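Fluorophenyl swap in a series resting at its limit

The source may hold more compounds than are shown below. What is called first, only, known or untested is meant among the compounds shown, and "the series" means these compounds.

Measured so far in a functional assay on Raji cells (Homo sapiens) for cytotoxicity, with a stated time of 72 h; a higher number here means that more compound is needed for the effect, a lower number that less compound is needed:
compound 1 `C=C[C@@](C)(/C=C/c1ccc(OC)cc1)CCC=C(C)C`: > 26000 nM, a limit
compound 2 `C=C[C@@](C)(/C=C/c1ccc(OCc2ccccc2)cc1)CCC=C(C)C`: > 26000 nM, a limit
compound 3 `C=C[C@@](C)(/C=C/c1ccc(Nc2ccc(OC)c(F)c2)cc1)CCC=C(C)C`: > 26000 nM, a limit

Compound 3 has no number of its own, only the limit > 26000 nM. Among the compounds with values here, the series so far shares this one reading: the limit of > 26000 nM in this assay, at which 3 of the 3 values shown sit. Within the data shown here, no compound can therefore be ranked against another.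

Compound 4 `C=C[C@@](C)(/C=C/c1ccc(Nc2ccc(F)cc2)cc1)CCC=C(C)C` differs from compound 3 in one place: 4-fluorophenyl in place of 3-fluoro-4-methoxyphenyl on a nitrogen on an aromatic ring. In words, 4-fluorophenyl stands in place of 3-fluoro-4-methoxyphenyl on a nitrogen on an aromatic ring.

Among the measured compounds shown here, the only measured step is a step that the two limits leave unreadable from compound 1 to compound 2. It lies elsewhere on the structure and has no readable size, so it offers no size to carry over to this change. The expectation rests instead on the shared limit, (the limit of > 26000 nM in this assay, at which 3 of the 3 values shown sit).

No step beyond the scatter is expected in this assay, and compound 4 will most likely report a limit again. Should a number appear, the only readable direction would be towards less compound needed. The estimated step is a number no higher from compound 3 to compound 4 (the limit leaves the size open). For compound 4 the expected value is 26000 nM. The estimated range runs from 9000 nM to 40000 nM.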

Compound 4, half-maximal effective concentration: > 26000 nM
Compound 4 gave a limit, no number; the forecaster's own chance of this, stated with the estimate: 75%; the middle value lies on the limit itself.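

No new step can be read: the steps to compound 4 from compound 1, compound 2 and compound 3 each join two limits in this assay. The series still rests on one reading: the limit of > 26000 nM in this assay, at which 4 of the 4 values shown sit. The compounds shown leave open whether any change on the shared core would give a number rather than a limit in this assay.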